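A few compounds are considered here, and "the series" means these few. Any claim that something is new, unique, unknown or untested is made for them only; others in the source may bear on it.

In a functional assay on PC-3 cells (Homo sapiens) for inhibition, read by sulforhodamine B assay, with a stated time of 72 h (a lower number here means a stronger inhibitor, a higher number a weaker inhibitor), compound 1 `Nc1sc(-c2ccc(Cl)cc2)c(-c2ccc(Cl)cc2)c1C(=O)N1CCCCC1=O` gives 4940 nM and compound 2 `Nc1sc(-c2ccc(Cl)cc2)c(-c2ccc(Cl)cc2)c1C(=O)NC1CCC(O)CC1` gives 5670 nM. Among the compounds with values here, compound 2 therefore stands level with the only other number available, and the two lie within the scatter of each other. Compound 3 `Nc1sc(-c2ccc(Cl)cc2)c(-c2ccc(Cl)cc2)c1C(=O)N1CCOCC1` keeps the shared core and carries morpholin-4-yl in place of (4-hydroxycyclohexyl)amino on a carbonyl carbon. Within the data shown here, one measured step bears on this, at the same carbonyl carbon, where (4-hydroxycyclohexyl)amino took the place of 2-oxopiperidin-1-yl. That step from compound 1 is a 1.1-fold higher number from compound 1 to compound 2 (0.06 log units; within the scatter), and on this single step no shift beyond the scatter is expected in this assay, in either direction. Among the measured compounds shown here, no measured compound yet carries morpholin-4-yl, so the range stays wide. The estimated step is a 1.0-fold lower number from compound 2 to compound 3 (0.01 log units; within the scatter). For compound 3 the expected value is 5500 nM, with an estimated range of 2500 nM to 12000 nM.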

Compound 3, half-maximal inhibitory concentration: 11700 nM
Compound 3: middle estimate off by 2.1-fold (0.33 log units), on the low side; the measured number falls inside the stated range.
By their numbers in this assay, from the lowest: compounds 1 and 2 (each within the scatter of the next); then compound 3.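

In this assay the carbonyl carbon now proves sensitive to what it carries: the earlier pair stayed within the scatter, whereas morpholin-4-yl gives a 2.1-fold higher number from compound 2 to compound 3 (0.31 log units; beyond the scatter) and a 2.4-fold higher number from compound 1 to compound 3 (0.37 log units; beyond the scatter), both modest and both towards a weaker inhibitor. Compound 3 thus sits apart from both earlier compounds, though the position has so far shown only a loss and no gain. The change from compound 2 swaps 8 heavy atoms and 2 hydrogen-bond donors for 6 heavy atoms and 0 donors, and nothing available accounts for the shift.

The compounds shown leave open whether any group at this carbonyl carbon gives a stronger inhibitor than compounds 1 and 2. A piperazin-1-yl ring, with nitrogen in place of the morpholine oxygen, or an open-chain amine such as dimethylamino, would test how far the shift extends.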